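This account rests on a few compounds, and the source may have more. Where it says the series, first, only, none or still open, it means among the compounds named here.

Working notes on the series, read in a functional assay on KB3 cells (Homo sapiens) for antiproliferative activity, read by MTT assay, with a stated time of 96 h; on this read-out higher numbers stand for weaker inhibition and lower numbers for stronger inhibition. Compound 1 `C=C(C)[C@H]1CC=C(C)[C@@]2(O)[C@@H]1[C@H](c1ccc(Cl)cc1Cl)O[C@@H]2C(=O)OCC` gives 3000 nM, the higher of the two actual numbers in hand. Compound 2 `C=C(C)[C@H]1CC=C(C)C2=CO[C@@H](c3ccccc3F)[C@@H]21` gives 1000 nM, and the gap between compound 1 and compound 2 lies beyond the usual scatter. Compound 3 `C=C(C)[C@H]1CC=C(C)[C@H]2[C@@H]1[C@H](c1ccccc1Br)O[C@@H]2C(=O)OCC` returns only a limit, > 100000 nM, and not a number.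

The next compound to be read is compound 4 `C=C(C)[C@H]1CC=C(C)[C@@]2(O)[C@@H]1[C@H](c1cccc(Cl)c1Cl)O[C@@H]2C(=O)OCC`. Against compound 1, it carries 2,3-dichlorophenyl in place of 2,4-dichlorophenyl on a saturated ring carbon, next to the ring oxygen: 2,3-dichlorophenyl in place of 2,4-dichlorophenyl on a saturated ring carbon. The two have the same atoms, joined differently, and the hydroxy and ethoxycarbonyl groups stay where they were.

Within the data shown here, no measured pair differs in one place only, so no measured step guides the size of this one. In this assay, no step beyond the scatter is expected in either direction, which leaves compound 1 at 3000 nM as the anchor. The expected change is small, as the estimated no change at the digits printed from compound 1 to compound 4 (within the scatter) shows. For compound 4 the estimated value is 3000 nM, with an expected range of 1000 nM to 10000 nM.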

Compound 4, half-maximal inhibitory concentration: 5000 nM
Beside the measured number, compound 4's estimate is 1.7-fold (0.22 log units) below it; the measured number falls inside the stated range.
By their numbers in this assay, from the lowest: compound 2; then compounds 1 and 4 (each within the scatter of the next). At a limit, above all of these: compound 3.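

In this assay, among these compounds, the step of a 1.7-fold higher number from compound 1 to compound 4 (0.22 log units; within the scatter) is the first one that can be read as a change in one place, and it lies within the scatter. On this saturated ring carbon, next to the ring oxygen, 2,3-dichlorophenyl and 2,4-dichlorophenyl therefore cannot be told apart on this read-out, even though the two compounds have the same atoms, joined differently, and the hydroxy and ethoxycarbonyl groups stay where they were. Nothing at hand bears on why the two isomers read alike.

The step covers only one rearrangement of two chlorines, so it leaves open how far this position tolerates a real change of group, such as a phenyl ring carrying an amine or a carboxylic acid, or a pyridine ring in place of the phenyl ring. Among the compounds shown here, the roles of the hydroxy and ethoxycarbonyl groups also remain open, as no step changes either of them on its own.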